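This account rests on a few compounds, and the source may have more. Where it says the series, first, only, none or still open, it means among the compounds named here.

Measured in a functional assay on PC-3 cells (Homo sapiens) for cytotoxicity, read by MTT assay, with a stated time of 72 h; a higher number here means a weaker inhibitor, a lower number a stronger inhibitor:
compound 1 `CNC(=O)c1cc(Oc2ccc(C3=NNC(c4ccc(C#N)cc4)C3)cc2)ccn1`: 9910 nM
compound 2 `CNC(=O)c1cc(Oc2ccc(C3=NNC(c4ccc(OC)cc4)C3)cc2)ccn1`: 7740 nM
compound 3 `CNC(=O)c1cc(Oc2ccc(C3=NNC(c4cccc(Cl)c4Cl)C3)cc2)ccn1`: "not determined" (no result reported)

Among the measured compounds shown here, compound 1 is one of only two compounds here with a number, and its value cannot be told apart from that of compound 2. For the measured compounds named here, the single measured step is a 1.3-fold lower number from compound 1 to compound 2 (0.11 log units; within the scatter), which puts methoxy in place of cyano on an aromatic carbon. Compound 3 offers no comparison, since its entry reads "not determined" (no result reported).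

Compound 4 `CNC(=O)c1cc(Oc2ccc(C3=NN(C(N)=S)C(c4ccc(C#N)cc4)C3)cc2)ccn1` keeps the whole of compound 1 except at one site: a group of 3 heavy atoms (1 carbon, 1 nitrogen, 1 sulfur; no ring) in place of a hydrogen atom, on an amine nitrogen in a ring. In plain terms, a small group replaces a hydrogen atom, on an amine nitrogen in a ring.

The measured step gives only weak guidance, as it concerns a different place in the molecule. Going by the values given here, no measured pair shows what a change on this ring nitrogen does. Among the compounds with values here, the small size of a 1.3-fold lower number from compound 1 to compound 2 (0.11 log units; within the scatter) shows only that one swap at the other site left the number within the scatter. Within the data shown here, no step clearly beyond the scatter is therefore expected, with a slight lean towards a lower number. The expected step is a 1.7-fold lower number from compound 1 to compound 4 (0.22 log units; within the scatter), and it is very uncertain. For compound 4 the estimated value is 6000 nM, with an expected range from 1500 nM to 20000 nM.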

Compound 4, half-maximal inhibitory concentration: > 50000 nM
Compound 4: only a limit was reported; the forecaster's own chance of this, stated with the estimate: 15%; middle value at least 8.3-fold (0.92 log units) from the limit.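

The ring nitrogen that carries only a hydrogen atom in compound 1 turns out to be a sensitive site in this assay: adding the small group there gives an at least 5.0-fold higher number from compound 1 to compound 4 (0.70 log units; beyond the scatter). The earlier change at the aromatic carbon gave a 1.3-fold lower number from compound 1 to compound 2 (0.11 log units; within the scatter), so this is the first single change among these compounds to move the result beyond the scatter, and it moves it towards a weaker inhibitor. The result for compound 4 is a limit of the assay and not a number, so the full size of the step remains unknown: the limit of > 50000 nM in this assay, at which 1 of the 4 values shown sits.

Among the compounds shown here, with only this one group on the ring nitrogen, it stays open whether the result depends on the sulfur, on the group's amine nitrogen, or on replacing that hydrogen atom at all, a question that a methyl or acetyl group at the same place could help to settle. On these data alone, it is also open whether the same group would have a similar effect with the methoxy group of compound 2 in place of the cyano group.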